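The source may report more compounds than this note shows. Statements on the series, on what has been measured and on what is new or still open speak of the compounds shown alone.

compound 1 `CCOC(=O)c1c(-c2cccc(OC)c2)[nH]c2cc(OC)ccc2c1=O`: > 21500 nM
compound 2 `CCCOc1cccc(-c2[nH]c3cc(OC)ccc3c(=O)c2C(=O)OCC)c1`: > 21500 nM

In an ADME assay on Raji cells (Homo sapiens) for cytotoxicity, read by luminescence, with a stated time of 72 h (a lower number here means that less compound is needed, a higher number that more compound is needed for the effect), compound 1 gives > 21500 nM, which is a limit of the assay and not a number. In this assay compound 2 gives > 21500 nM, again a limit. The step that the two limits leave unreadable from compound 1 to compound 2 is thus unreadable. Compound 2 stands at the limit of > 21500 nM in this assay, at which 2 of the 2 values shown sit, with no number of its own. Compound 3 `CCOC(=O)c1c(-c2cccc(Cl)c2)[nH]c2cc(OC)ccc2c1=O` differs from compound 2 by chloro in place of propoxy on an aromatic carbon. For the measured compounds named here, no measured step bears on this change, since the only one known is unreadable. Compound 3 is expected at 30000 nM, between 15000 nM and 100000 nM, most likely again only a limit. The expected step is a step that the limit leaves unreadable from compound 2 to compound 3.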

Compound 3, half-maximal effective concentration in the Raji assay: > 21500 nM
Compound 3 gave a limit, no number; the forecaster's own chance of this, stated with the estimate: 75%; the middle value does not contradict the limit.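

In the Raji assay compound 3 gives > 21500 nM, which is a limit of the assay and not a number. No step among compound 1, compound 2 and compound 3 can be read in the Raji assay, since each gives only a limit of the assay, not a number: the limit of > 21500 nM in the Raji assay, at which 3 of the 3 values shown sit.

In a physicochemical assay for solubility, at pH 7.4 (a higher number here means a more soluble compound, a lower number a less soluble compound), compound 2 gives 5800 nM and compound 3 gives 58000 nM; this is a 10-fold higher number from compound 2 to compound 3 (1.00 log units; beyond the scatter).

The compounds shown leave open whether any group in this place gives a readable number in the Raji assay.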